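A few compounds are considered here, and "the series" means these few. Any claim that something is new, unique, unknown or untested is made for them only; others in the source may bear on it.

Measured compounds:
- Compound 1 `COc1cc(-c2cc(/C=C/C(=O)c3ccc(C)c(C)c3)nc3cc(-c4ccccc4)nn23)cc(OC)c1OC`: 72500 nM
- Compound 2 `COc1ccc(C(=O)/C=C/c2cc(-c3ccc(OC)c(OC)c3)n3nc(-c4ccccc4)cc3n2)cc1`: 40000 nM
- Compound 3 `COc1ccc(-c2cc(/C=C/C(=O)c3ccccc3)nc3cc(-c4ccccc4)nn23)cc1`: 53200 nM

In an ADME assay on HEK293 cells (Homo sapiens) for antiproliferative activity, read by MTT assay, with a stated time of 24 h (on this read-out lower numbers stand for stronger inhibition and higher numbers for weaker inhibition), compound 1 gives 72500 nM, the largest of the three numbers; its gap to compound 3 and its gap to compound 2 both lie within the scatter of repeated measurements, so the three compounds are not separated by these data. Compound 4 `COc1cc(-c2cc(/C=C/C(=O)c3ccc(Cl)cc3)nc3cc(-c4ccccc4)nn23)cc(OC)c1OC` shares the core of compound 1 and differs from it only at the carbonyl carbon: 4-chlorophenyl in place of 3,4-dimethylphenyl on a carbonyl carbon. Within the data shown here, no measured pair in this set isolates that change, so there is no measured step to lean on. Given that compound 1 sits at 72500 nM in this assay and that the other two compounds fall within the scatter of it, the step of a 1.2-fold lower number from compound 1 to compound 4 (0.08 log units; within the scatter) is expected to be small, not beyond the scatter, with no clear direction. Compound 4 is therefore estimated at 60000 nM in this assay, with a range from 25000 nM to 140000 nM.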

Compound 4, half-maximal inhibitory concentration: >= 100000 nM
Compound 4: only a limit was reported; the forecaster's own chance of this, stated with the estimate: 15%; at least 1.6-fold (0.22 log units) between middle value and limit.
By their numbers in this assay, from the lowest: compounds 2, 3 and 1 (each within the scatter of the next). At a limit, above all of these: compound 4.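

In this assay, compound 4 gives >= 100000 nM, which is a limit of the assay and not a number. Among these compounds, the swap of 4-chlorophenyl for 3,4-dimethylphenyl on a carbonyl carbon now gives the one measured step in this set, an at least 1.3-fold higher number from compound 1 to compound 4 (0.13 log units; that floor lies within the scatter), which the earlier compounds, with no pair differing in one place, could not supply. Only the floor of that step can be stated, so the data fix neither its full size nor any separation of the two compounds, and the reading rests on a single value at the edge of the assay: the limit of >= 100000 nM in this assay, at which 1 of the 4 values shown sits.

From the compounds shown here alone, how a 4-aminophenyl or a 4-carboxyphenyl on this carbonyl carbon would read in this assay remains open. Also open, going by these compounds, is how far the step from the 3,4-dimethylphenyl group really extends past its floor.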